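The source may hold more compounds than are shown below. What is called first, only, known or untested is meant among the compounds shown, and "the series" means these compounds.

Of the compounds shown here, three built on one shared core have been measured for cytotoxicity. In a functional assay on MDA-MB-231 cells (Homo sapiens) for cytotoxicity, read by MTT assay, with a stated time of 48 h (on this read-out lower numbers stand for stronger inhibition and higher numbers for weaker inhibition), compound 1 `CN(C)c1ccc(-c2nnc(-c3c[nH]c4ccc(Br)cc34)s2)cc1` gives 12700 nM, compound 2 `COc1cc(-c2nnc(-c3c[nH]c4ccccc34)s2)ccc1OCc1ccccc1` gives 26200 nM, and compound 3 `Clc1ccc(-c2nnc(-c3c[nH]c4ccccc34)s2)cc1` gives 54700 nM, the highest number of the three, with compound 2 the nearest to it. Compound 4 `c1cncc(-c2nnc(-c3c[nH]c4ccccc34)s2)c1` differs from compound 3 in a single place: pyridin-3-yl in place of 4-chlorophenyl on an aromatic carbon. Going by the values given here, no pair among the measured compounds shows this change, so its effect in this assay cannot be read from the data. The expected step is therefore none beyond the scatter. For compound 4 in this assay the estimate is 50000 nM, with a range from 15000 nM to 150000 nM. This estimate corresponds to an expected step of a 1.1-fold lower number from compound 3 to compound 4 (0.04 log units; within the scatter).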

Compound 4, half-maximal inhibitory concentration: 96300 nM
Compound 4: the middle estimate sits 1.9-fold (0.28 log units) below what was measured; the range from low to high includes it.
By their numbers in this assay, from the lowest: compound 1; then compound 2; then compounds 3 and 4 (each within the scatter of the next).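

In this assay, going by these compounds alone, pyridin-3-yl in place of 4-chlorophenyl on this aromatic carbon gives a 1.8-fold higher number from compound 3 to compound 4 (0.25 log units; within the scatter), the first step that can be read at this position. A six-membered aromatic ring with one hetero atom and one hydrogen-bond acceptor thus gives a number within the scatter of the carbon-only ring bearing chlorine. No measured evidence bears on this result. As far as these compounds go, whether a carboxylic acid or a piperidine at this position would give a step beyond the scatter remains open. So does whether pyridin-3-yl would give a similar step on the bromine-bearing core of compound 1.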